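The source may report more compounds than this note shows. Statements on the series, on what has been measured and on what is new or still open speak of the compounds shown alone.

Measured compounds in a functional assay on HepG2 cells (Homo sapiens) for antiproliferative activity, read by MTT assay, with a stated time of 48 h; a lower number here means a stronger inhibitor, a higher number a weaker inhibitor:

compound 1 `COc1ccc(-c2ccc3c(c2)C(=O)C(=O)N3c2ccc(OC)cc2)cc1`: > 10000 nM; this is a limit of the assay, not a number (the limit of > 10000 nM in this assay, at which 1 of the 3 values shown sits).
compound 2 `COc1ccc(-c2ccc3c(c2)C(=O)C(=O)N3Cc2ccc(C#N)cc2)cc1`: 1000 nM.
compound 3 `COc1ccc(CN2C(=O)C(=O)c3cc(-c4cc(OC)cc(OC)c4)ccc32)cc1`: 1200 nM.

Of the two numbers shown, compound 3 sits at the upper end, yet compound 2 lies within the scatter of it, so the two cannot be separated. Among the compounds with values here, the single measured step, an at least 10-fold lower number from compound 1 to compound 2 (1.00 log units; beyond the scatter), concerns the group on the amide-type nitrogen in a ring and leaves the aryl on the aromatic carbon untouched.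

Compound 4 `COc1ccc(CN2C(=O)C(=O)c3cc(-c4ccc(C(F)(F)F)cc4)ccc32)cc1` differs from compound 3 at that carbon only: 4-(trifluoromethyl)phenyl in place of 3,5-dimethoxyphenyl on an aromatic carbon. Within the data shown here, no measured step touches this position, and the substituent on the nitrogen is the same in both, so the data give no direction for the change. The step expected in this assay is therefore no change at the digits printed from compound 3 to compound 4 (within the scatter), nothing beyond the scatter, with a wide range to reflect the absence of any comparable pair. Compound 4 is estimated at 1200 nM, between 400 nM and 4000 nM.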

Compound 4, half-maximal inhibitory concentration: 820 nM
For compound 4 the middle estimate is 1.5-fold (0.17 log units) above the measured one; the measured number falls inside the stated range.
By their numbers in this assay, from the lowest: compounds 4, 2 and 3 (each within the scatter of the next). At a limit, above all of these: compound 1.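

In this assay, the aryl on the aromatic carbon now has a measured step, with the substituent on the nitrogen held constant: a 1.5-fold lower number from compound 3 to compound 4 (0.17 log units; within the scatter). The 4-(trifluoromethyl)phenyl and 3,5-dimethoxyphenyl groups therefore cannot be separated at this position, and in this pair a change from 2 hydrogen-bond acceptors to 0 in the group, at an equal 10 heavy atoms, leaves the number within the scatter. No measured property of these compounds bears on this step.

Still open, on these data alone, is whether an amine or a carboxylic acid on this aryl, or a saturated ring in its place, would move the number beyond the scatter. No pair shown changes this aryl with 4-cyanobenzyl on the nitrogen, so whether the result carries over to that substituent also remains unknown.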